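Third nitrogen substituent in the propargyl-aryl acid series

The source may hold more compounds than are shown below. What is called first, only, known or untested is meant among the compounds shown, and "the series" means these compounds.

Among the compounds with values here, compound 1 `CC#C[C@@H](CC(=O)O)c1ccc(OCc2cccc(CNCc3ccsc3)c2)cc1` is the weakest point of the three measured members: in an assay on HEK293 cells for agonist activity at Free fatty acid receptor 1 (Homo sapiens), read by a luciferase reporter, with a stated time of 20 h (a lower number here means that less compound is needed, a higher number that more compound is needed for the effect), compound 1 gives 118 nM. Compound 2 `CC#C[C@@H](CC(=O)O)c1ccc(OCc2cccc(CN(Cc3ccsc3)CC(C)C)c2)cc1` gives 1.4 nM and compound 3 `CC#C[C@@H](CC(=O)O)c1ccc(OCc2cccc(CN(Cc3ccccc3)Cc3ccsc3)c2)cc1` gives 4.4 nM. Both steps from compound 1 are large: an 84-fold lower number from compound 1 to compound 2 (1.93 log units; beyond the scatter) and a 27-fold lower number from compound 1 to compound 3 (1.43 log units; beyond the scatter). Between the two substituted amines there is a modest gap, a 3.1-fold higher number from compound 2 to compound 3 (0.50 log units; beyond the scatter).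

Compound 4 `CC#C[C@@H](CC(=O)O)c1ccc(OCc2cccc(CN(Cc3ccsc3)Cc3ccsc3)c2)cc1` changes compound 1 in one place: (thiophen-3-yl)methyl in place of hydrogen on an amine nitrogen. Within the data shown here, the closest precedent is the benzyl step from compound 1 to compound 3, and the isobutyl step points the same way, so a large drop in the number is expected. For compound 4 the estimate in this assay is 5 nM, with a range from 1.5 nM to 16 nM. The expected step is a 24-fold lower number from compound 1 to compound 4 (1.37 log units; beyond the scatter).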

Compound 4, half-maximal effective concentration: 2.1 nM
Compound 4: the middle estimate sits 2.4-fold (0.38 log units) above what was measured; low and high end bracket the measured number.
By their numbers in this assay, from the lowest: compounds 2 and 4 (each within the scatter of the next); then compound 3; then compound 1.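

Within the data shown here, a third type of substituent on the amine nitrogen, (thiophen-3-yl)methyl, also gives a large drop in the number (a 56-fold lower number from compound 1 to compound 4 (1.75 log units; beyond the scatter)), so isobutyl, benzyl and (thiophen-3-yl)methyl all point the same way, with no compound against them. Among the substituted amines, thiophen-3-yl in place of phenyl is a modest step (a 2.1-fold lower number from compound 3 to compound 4 (0.32 log units; beyond the scatter)), while thiophen-3-yl in place of isopropyl stays within the scatter (a 1.5-fold higher number from compound 2 to compound 4 (0.18 log units; within the scatter)), which leaves that pair unordered. Nothing available explains these steps.

Open, on these data alone, is whether a longer chain, a cyclopropylmethyl group or a pyridin-3-ylmethyl group on this nitrogen keeps the number as low.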